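The compounds below may be only part of what the source reports. "The series", "measured", "known", "first", "only" and "open" are said of these compounds alone.

Measured so far in a functional assay on SMMC-7721 cells (Homo sapiens) for inhibition, read by CCK-8 assay, with a stated time of 72 h; a higher number here means a weaker inhibitor, a lower number a stronger inhibitor:
- compound 1 `O=C(NO)c1ccc(CNC(=O)c2n[nH]cc2NC(=O)c2c(Cl)cccc2Cl)cc1` gives 14600 nM
- compound 2 `COc1ccccc1C(=O)Nc1c[nH]nc1C(=O)NCc1ccc(C(=O)Nc2ccccc2N)cc1` gives 8320 nM

Compound 1 sits level with compound 2, as the gap between their two values lies within the usual scatter. Within the data shown here, the two compounds differ in more than one place, so this pair isolates no single change, and no measured step shows how much a change at any one place matters.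

The next compound to be read in this assay is compound 3 `O=C(NO)c1ccc(CNC(=O)c2n[nH]cc2NC(=O)c2ccccc2F)cc1`, which keeps the core of compound 1 and changes only the group on the carbonyl carbon. The difference is 2-fluorophenyl in place of 2,6-dichlorophenyl on a carbonyl carbon.

Among the measured compounds shown here, with no measured step to scale it, only a modest shift toward a lower number is expected, and it may not clear the scatter. The expected move is a 1.8-fold lower number from compound 1 to compound 3 (0.26 log units; within the scatter) (an estimate with wide uncertainty). For compound 3 the estimated value is 8000 nM, with an expected range from 2500 nM to 25000 nM (estimated ends).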

Compound 3, half-maximal inhibitory concentration: 16700 nM
For compound 3 the middle estimate is 2.1-fold (0.32 log units) below the measured one; the range from low to high includes it.
By their numbers in this assay, from the lowest: compounds 2, 1 and 3 (each within the scatter of the next).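

In this assay, among these compounds, the first step that isolates one place reads a 1.1-fold higher number from compound 1 to compound 3 (0.06 log units; within the scatter), for 2-fluorophenyl in place of 2,6-dichlorophenyl on a carbonyl carbon whose other neighbour is an amide-type nitrogen. This exchange of one halogen-bearing phenyl group for another therefore leaves the reading level, which gives this position its first measured scale, though only for this single pair. No available data explain this outcome.

Going by these compounds, whether the position responds to a larger change remains open, as both groups compared are halogen-bearing phenyl groups, and a cyclohexyl group, a phenyl group carrying an amine or a carboxylic acid, or a longer alkyl chain on the same carbonyl carbon could still give a different reading. Steps involving compound 2 cannot be read, as it differs from compound 1 and compound 3 in more than one place, so what the other parts of these structures contribute also remains open.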